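The source may hold more compounds than are shown below. What is called first, only, known or untested is meant among the compounds shown, and "the series" means these compounds.

Working notes on the oxazolone series in a functional assay on the whole organism with Mus musculus as the target, read by paw edema, with a stated time of 360 min, at a dose of 50 mg/kg by the oral route; a lower number here means a stronger effect, a higher number a weaker effect of the compound at the dose given.

Three compounds carry a measurement. Compound 1 `CNc1nnc(Cn2c(=O)oc3ccc(C)cc32)s1` gives 96% in this assay. Compound 2 `Cc1ccc2oc(=O)n(Cc3n[nH]c(=S)n3C)c2c1` gives 97.8%. Compound 3 `Cc1ccc2oc(=O)n(CC(=O)NN)c2c1` gives 101%. The gap from compound 3 to compound 2 and the gap from compound 3 to compound 1 both lie within the scatter, so the three numbers cannot be told apart; compound 3 sits with the others at the top of the percentage range, and no order among them is claimed.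

Compound 4 `CCCNC(=S)NNC(=O)Cn1c(=O)oc2ccc(C)cc21` has not yet been measured. It differs from compound 3 in one place: a group of 6 heavy atoms (4 carbon, 1 nitrogen, 1 sulfur; no ring) in place of a hydrogen atom, on an amine nitrogen. Within the data shown here, no step between measured compounds is available, so no measured step bears on the size of this change.

Given that compound 1, compound 2 and compound 3 all sit at the same level regardless of the group on the core nitrogen, the expected step for compound 4 is a number 6 percentage points lower from compound 3 to compound 4 (within the scatter), that is, none beyond the scatter. Compound 4 is accordingly estimated at 95%, within a range from 84% to 106%.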

Compound 4, a percentage reported as activity, at one dose (the size of the read-out at that dose, not a potency): 177%
For compound 4 the middle estimate is 82 percentage points below the measured one, and the stated range ends below it.
By their numbers in this assay, from the lowest: compounds 1, 2 and 3 (each within the scatter of the next); then compound 4.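

In this assay, the amine nitrogen whose other neighbour is an amide-type nitrogen proves to be a place where a change registers: a group of 6 heavy atoms (4 carbon, 1 nitrogen, 1 sulfur; no ring) in place of a hydrogen atom gives a number 76 percentage points higher from compound 3 to compound 4 (beyond the scatter). As a higher number means a weaker effect, this single step runs towards a weaker effect at the dose given, and it separates a pair of compounds by more than the scatter. No measurement shown accounts for the size or direction of this step.

Going by these compounds, it remains open whether a single methyl group on the same amine nitrogen would shift the number as well, or whether the shift requires the whole entering group. Also open, on these data alone, is whether an oxygen in place of the sulfur, or a shorter or longer chain than the propyl chain, would preserve the step.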